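From a methyl group to a hexyloxy chain

The source may hold more compounds than are shown below. What is called first, only, known or untested is meant among the compounds shown, and "the series" means these compounds.

In a functional assay on A549 cells (Homo sapiens) for antiproliferative activity, read by MTT assay, with a stated time of 48 h (on this read-out higher numbers stand for weaker inhibition and lower numbers for stronger inhibition), three compounds sharing one core have been measured. Compound 3 `COc1ccc(/C=C/c2cc(OC)cc(OC)c2/C=C/C(=O)c2ccc(C)cc2)cc1` gives 3.6 ug/mL, at the low end of these numbers. Compound 2 `COc1ccc(/C=C/c2cc(OC)cc(OC)c2/C=C/C(=O)c2cccc(OC)c2)cc1` gives 6.1 ug/mL, a value within the scatter of compound 3. Compound 1 `CCCCCCCCCCCCOc1ccc(C(=O)/C=C/c2c(/C=C/c3ccc(OC)cc3)cc(OC)cc2OC)cc1` gives 7.9 ug/mL, and its gap to compound 3 lies beyond the scatter.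

Compound 4 `CCCCCCOc1ccc(C(=O)/C=C/c2c(/C=C/c3ccc(OC)cc3)cc(OC)cc2OC)cc1` has not yet been measured. It differs from compound 3 in one place: hexyloxy in place of methyl on an aromatic carbon. Hexyloxy stands in place of methyl on an aromatic carbon, para to a large group.

Going by the values given here, the only measured single change is a 1.7-fold lower number from compound 2 to compound 3 (0.23 log units; within the scatter), which puts 4-methylphenyl in place of 3-methoxyphenyl on a carbonyl carbon. That step stays within the scatter and offers only weak guidance. Compound 1 is the closer relative, since it holds the longer dodecyloxy where compound 4 holds hexyloxy. With compound 1 at 7.9 ug/mL, a value between those of compound 3 and compound 1 seems likely, although a single long chain establishes no trend. The expected change is a 1.7-fold higher number from compound 3 to compound 4 (0.22 log units; within the scatter), a modest rise that would not clear the scatter. For compound 4 the estimated value is 6 ug/mL, with an expected range of 3 ug/mL to 12 ug/mL.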

Compound 4, half-maximal inhibitory concentration: 8.4 ug/mL
For compound 4 the middle estimate is 1.4-fold (0.15 log units) below the measured one; low and high end bracket the measured number.
By their numbers in this assay, from the lowest: compounds 3, 2, 1 and 4 (each within the scatter of the next, the first and the last beyond it).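

In this assay, going by these compounds alone, hexyloxy in place of methyl on an aromatic carbon, para to a large group, gives a 2.3-fold higher number from compound 3 to compound 4 (0.37 log units; beyond the scatter) and so provides the first single change at this position that clears the usual scatter, which shows that the number does respond to what sits on this carbon. The dodecyloxy chain of compound 1 and the hexyloxy chain of compound 4 cannot be told apart on this read-out, with a 1.1-fold higher number from compound 1 to compound 4 (0.03 log units; within the scatter) and the two values lying within the scatter of each other, so the length of the chain beyond hexyloxy has no readable effect across this pair. Nothing available explains why the methyl and hexyloxy compounds differ.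

On these data alone, whether an ethoxy or butoxy chain on this carbon would give a number close to that of compound 3 or close to that of compound 4 remains open, so the chain length at which the difference appears is unknown. Also open, as far as these compounds go, is how an amine or a carboxylic acid in place of methyl on this aromatic carbon would read in this assay.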